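From Compound 3 to Compound 4: One Stereocentre Redrawn

The source may hold more compounds than are shown below. What is called first, only, known or untested is meant among the compounds shown, and "the series" means these compounds.

compound 1 `CCCCNC(=O)CCCOc1ccc(C(=O)c2c(CCCC)oc3ccccc23)cc1` gives > 50000 nM
compound 2 `CCCCc1oc2ccccc2c1C(=O)c1ccc(OCCCC(=O)NCc2ccccc2)cc1` gives 28900 nM
compound 3 `CCCCc1oc2ccccc2c1C(=O)c1ccc(OCCCC(=O)N[C@@H](C)c2ccccc2)cc1` gives > 50000 nM

These values come from a functional assay on HL-60 cells (Homo sapiens) for antiproliferative activity, read by MTT assay, with a stated time of 24 h (on this read-out higher numbers stand for weaker inhibition and lower numbers for stronger inhibition), and only one of them is a number. Compound 2 supplies that number, 28900 nM, in this small set. Compound 1 has only a limit, > 50000 nM, and no number. Compound 3 likewise has only a limit, > 50000 nM, and no number. Compound 3 therefore stands at the limit of > 50000 nM in this assay, at which 2 of the 3 values shown sit, and cannot be placed more exactly.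

Compound 4 `CCCCc1oc2ccccc2c1C(=O)c1ccc(OCCCC(=O)N[C@H](C)c2ccccc2)cc1` is the next to be measured. Against compound 3, the two compounds have the same atoms and bonds and differ only in configuration as drawn: 1 of 1 stereo elements differ; a stereocentre at a saturated chain carbon is drawn S in compound 3 and R in compound 4 and nothing else changes.

Among the compounds with values here, no measured step alters configuration at this carbon. The nearest is an at least 1.7-fold higher number from compound 2 to compound 3 (0.23 log units; that floor lies within the scatter) and it puts in the methyl that carries the stereocentre. As far as these compounds go, it gives only a floor, so its true size remains open. The other route to compound 3 is a step that the two limits leave unreadable from compound 1 to compound 3 and it adds nothing readable. The step of an at least 1.7-fold lower number from compound 1 to compound 2 (0.23 log units; that floor lies within the scatter) concerns a different change and bears on this one only loosely.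

No step beyond the scatter can be firmly expected, and the direction is open. The expected change is an at least 1.1-fold lower number from compound 3 to compound 4 (0.04 log units; that floor lies within the scatter) and it rests on the limit of compound 3, so its size is uncertain. Compound 2 at 28900 nM marks the likely strong end of the range. For compound 4 the estimate is 45000 nM with an expected range from 18000 nM to 100000 nM and a limit instead of a number is about as likely as not.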

Compound 4, half-maximal inhibitory concentration: > 50000 nM
Compound 4 gave a limit, no number; the forecaster's own chance of this, stated with the estimate: 55%; at least 1.1-fold (0.04 log units) between middle value and limit.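

In this assay the saturated chain carbon that carries the methyl has now been read in both drawn configurations, S in compound 3 and R in compound 4, and neither gives a number, only a limit of the assay. Methyl in place of hydrogen on this carbon now gives the same kind of reading in the R form as in the S form, an at least 1.7-fold higher number from compound 2 to compound 4 (0.23 log units; that floor lies within the scatter), so the change is still a floor and no firm loss can be claimed for either form. The steps that reach compound 4 from compound 3 and from compound 1 cannot be read, so this set gives no size or direction for the change of configuration, only a shared reading for two compounds alike in every other respect: the fact that compounds 3 and 4 differ only in the configuration as drawn

As far as these compounds go, how far each of the two forms truly lies from the other, and from compound 2, stays open, as the readings pile up at one value: the limit of > 50000 nM in this assay, at which 3 of the 4 values shown sit. Also open is whether an amine, a carboxylic acid or a longer chain in place of the 1-phenylethyl on the amide-type nitrogen would give a number in this assay.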